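The source may report more compounds than this note shows. Statements on the series, on what has been measured and on what is new or still open speak of the compounds shown alone.

Working notes on the series. In a functional assay on A-375 cells (Homo sapiens) for cytotoxicity, read by CCK-8 assay, with a stated time of 24 h (a lower number here means a stronger inhibitor, a higher number a weaker inhibitor), compound 1 (`COc1ccccc1Oc1c(N)nc(Cc2ccccc2)nc1OCCO`) gives 200 nM and compound 2 (`COc1ccccc1Oc1c(N)nc(-c2cccc(C)c2)nc1OCCO`) gives 1380 nM. Compound 2 therefore holds the higher, weaker number of the two, and the gap between them lies beyond the scatter. The next compound is compound 3 (`COc1ccccc1Oc1c(N)nc(-c2ccccc2F)nc1OCCO`), which has 2-fluorophenyl in place of 3-methylphenyl on an aromatic carbon of the shared core: 2-fluorophenyl in place of 3-methylphenyl on an aromatic carbon.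

For the measured compounds named here, only one measured step bears on this change: a 6.9-fold higher number from compound 1 to compound 2 (0.84 log units; beyond the scatter). It is a modest step at the same place, with 3-methylphenyl in place of benzyl. Going by the values given here, it does not compare two phenyl groups directly, and no measured pair does, so its size cannot simply be carried over. In this assay, a smaller step is expected, with no clear direction beyond a slight lean towards a lower number. The expected change is a 1.3-fold lower number from compound 2 to compound 3 (0.10 log units; within the scatter), and this is an estimate only. For compound 3 the estimated value is 1100 nM, with an expected range from 400 nM to 3000 nM.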

Compound 3, half-maximal inhibitory concentration: > 80000 nM
Compound 3 gave a limit, no number; the forecaster's own chance of this, stated with the estimate: 3%; middle value at least 72-fold (1.86 log units) from the limit.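

In this assay, compound 3 gives a limit of the assay and not a number: the limit of > 80000 nM in this assay, at which 1 of the 3 values shown sits. This place on the shared core proves far more sensitive than the earlier pair showed: exchanging one substituted phenyl group for another gives an at least 57-fold higher number from compound 2 to compound 3 (1.76 log units; beyond the scatter), and measured against the benzyl compound the change gives an at least 400-fold higher number from compound 1 to compound 3 (2.60 log units; beyond the scatter). For the compounds shown here, both steps exceed the one earlier step at this place, a 6.9-fold higher number from compound 1 to compound 2 (0.84 log units; beyond the scatter), even though 3-methylphenyl and 2-fluorophenyl have equal heavy-atom counts and neither has a hydrogen-bond donor or acceptor, so matching on these counts does not preserve the read-out.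

The compounds shown change the identity and the ring position of the substituent together, so they cannot say whether the loss follows the fluorine, its ring position or the absence of the methyl group; an unsubstituted phenyl, 3-fluorophenyl or 2-methylphenyl group would separate these. Also open, going by these compounds, is whether a longer chain such as 2-phenylethyl at this place would keep or improve on the value of compound 1, 200 nM.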